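Naphthalen-2-yl in Place of 2-Methylphenyl

A few compounds are considered here, and "the series" means these few. Any claim that something is new, unique, unknown or untested is made for them only; others in the source may bear on it.

In a functional assay on A549 cells (Homo sapiens) for inhibition, read by MTT assay, with a stated time of 72 h (on this read-out lower numbers stand for stronger inhibition and higher numbers for weaker inhibition), compound 1 (`Cc1cc(C)cc(CN2CCc3ncn(COCc4ccccc4)c3/C(=C/c3ccccc3)C2=O)c1`) gives 22500 nM. Compound 2 (`Cc1ccccc1CN1CCc2ncn(COCc3ccccc3)c2/C(=C/c2ccccc2)C1=O`) gives 25600 nM, and these two values lie within the scatter of each other, so the measurements so far do not separate compound 2 from compound 1. Compound 3 (`O=C1/C(=C\c2ccccc2)c2c(ncn2COCc2ccccc2)CCN1Cc1ccc2ccccc2c1`) has not yet been measured. It shares the core of compound 2 and differs in one group: naphthalen-2-yl in place of 2-methylphenyl on a saturated chain carbon bound to an amide-type nitrogen in a ring. Within the data shown here, only one measured step bears on this place, a 1.1-fold higher number from compound 1 to compound 2 (0.06 log units; within the scatter), and it stayed within the scatter. That single step involves no naphthalen-2-yl group, so its guidance is limited. Because a 1.1-fold higher number from compound 1 to compound 2 (0.06 log units; within the scatter) was so small, no step beyond the scatter is expected in this assay. The estimated step is a 1.3-fold lower number from compound 2 to compound 3 (0.11 log units; within the scatter), which would stay within the scatter. The expected value for compound 3 is 20000 nM, with an estimated range from 9000 nM to 45000 nM.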

Compound 3, half-maximal inhibitory concentration: 26400 nM
Beside the measured number, compound 3's estimate is 1.3-fold (0.12 log units) below it; low and high end bracket the measured number.
By their numbers in this assay, from the lowest: compounds 1, 2 and 3 (each within the scatter of the next).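

In this assay, naphthalen-2-yl on a saturated chain carbon bound to an amide-type nitrogen in a ring gives a 1.0-fold higher number from compound 2 to compound 3 (0.01 log units; within the scatter), and set against 3,5-dimethylphenyl at the same place it gives a 1.2-fold higher number from compound 1 to compound 3 (0.07 log units; within the scatter). Among these compounds, the earlier pair compared only two methyl-bearing phenyl groups, whereas this place now also carries a group of 10 heavy atoms with 2 six-membered aromatic rings, and this read-out still does not separate the three compounds. No evidence at hand accounts for this result.

Going by these compounds, all three groups at this place are made of carbon only and have no hydrogen-bond donors or acceptors, so it remains open whether an amine, a carboxylic acid or a pyridine ring there would give a number outside the scatter of these three. The compounds shown also keep the rest of the shared core unchanged, so they say nothing about how a change elsewhere on it would read in this assay.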